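From Trifluoromethyl to Trifluoromethoxy in an Antiproliferative Series

The compounds below may be only part of what the source reports. "The series", "measured", "known", "first", "only" and "open" are said of these compounds alone.

Of the compounds shown here, two have been measured so far in a functional assay on MDA-MB-436 cells (Homo sapiens) for antiproliferative activity, read by MTT assay, with a stated time of 24 h; on this read-out higher numbers stand for weaker inhibition and lower numbers for stronger inhibition. Among the compounds with values here, compound 1 `N#Cc1ccc(S(=O)(=O)NC(CC(=O)O)c2ccccc2)cc1` gives 59300 nM, and compound 2 `O=C(O)CC(NS(=O)(=O)c1ccc(C(F)(F)F)cc1)c1ccccc1` gives 54700 nM, so compound 2 stands level with its only neighbour, within the scatter. The next structure, compound 3 `O=C(O)CC(NS(=O)(=O)c1ccc(OC(F)(F)F)cc1)c1ccccc1`, carries trifluoromethoxy in place of trifluoromethyl on an aromatic carbon, para to a large group: trifluoromethoxy in place of trifluoromethyl on an aromatic carbon.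

Within the data shown here, only one measured step bears on this change. Trifluoromethyl in place of cyano on an aromatic carbon gave a 1.1-fold lower number from compound 1 to compound 2 (0.04 log units; within the scatter), so that exchange left this assay without a change beyond the scatter. Among the measured compounds shown here, this is a single step involving a different pair of groups, and no measured compound yet carries trifluoromethoxy. On the strength of that one flat step, no shift beyond the scatter is expected, and the data favour no direction. The expected step is a 1.0-fold higher number from compound 2 to compound 3 (0.00 log units; within the scatter). For compound 3 the estimated value is 55000 nM, with an expected range from 30000 nM to 100000 nM.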

Compound 3, half-maximal inhibitory concentration: > 100000 nM
Compound 3: a limit, no number (the forecaster's own chance of this, stated with the estimate: 8%); middle value at least 1.8-fold (0.25 log units) from the limit.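

In this assay compound 3 gives a limit of the assay and not a number: the limit of > 100000 nM in this assay, at which 1 of the 3 values shown sits. Trifluoromethoxy in place of trifluoromethyl, on an aromatic carbon para to a large group, gave an at least 1.8-fold higher number from compound 2 to compound 3 (0.26 log units; that floor lies within the scatter), and trifluoromethoxy in place of cyano at that same place gave an at least 1.6-fold higher number from compound 1 to compound 3 (0.22 log units; that floor lies within the scatter). Both are floors and not sizes, so neither step can be called a change beyond the scatter, yet this position, which had looked flat in the earlier exchange of a 1.1-fold lower number from compound 1 to compound 2 (0.04 log units; within the scatter), now holds a group whose reading ends at the limit and not at a number.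

As far as these compounds go, how far compound 3 truly lies from compound 1 and compound 2 stays open, since its reading gives only a floor for each step. Also open, from the compounds shown here alone, is whether a methoxy group, an amine or a longer chain at this position would return a number in this assay or another limit, and whether the single oxygen that separates trifluoromethoxy from trifluoromethyl is what matters here.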